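Swapping the amine substituent on a tetralin sulfone series

This account rests on a few compounds, and the source may have more. Where it says the series, first, only, none or still open, it means among the compounds named here.

Compound 1: `CN(C[C@@H]1CCCc2cc(S(=O)(=O)c3cccc(F)c3)ccc21)S(N)(=O)=O`, 3.98 nM
Compound 2: `NC(=O)CNC[C@@H]1CCCc2cc(S(=O)(=O)c3cccc(F)c3)ccc21`, 0.1 nM
Compound 3: `CN(CC(N)=O)C[C@@H]1CCCc2cc(S(=O)(=O)c3cccc(F)c3)ccc21`, 1.26 nM

In an assay on isolated protein for displacement of a labelled ligand from 5-hydroxytryptamine receptor 6 (Homo sapiens) (on this read-out higher numbers stand for weaker inhibition and lower numbers for stronger inhibition), compound 3 stands second highest of the three numbers, with compound 1 giving a higher number and compound 2 a lower one. Compound 4 is `COCCNC[C@@H]1CCCc2cc(S(=O)(=O)c3cccc(F)c3)ccc21`; the change is (2-methoxyethyl)amino in place of (carbamoylmethyl)(methyl)amino on a saturated chain carbon bound to a saturated ring carbon. Among the compounds with values here, two measured steps bear on it: the methyl on the amine nitrogen cost a lot, a 13-fold higher number from compound 2 to compound 3 (1.10 log units; beyond the scatter), while swapping the amine substituent gave a 3.2-fold lower number from compound 1 to compound 3 (0.50 log units; beyond the scatter). On these data alone, removing the methyl should therefore lower the number, though the methoxyethyl group is untested. The expected step is a 3.9-fold lower number from compound 3 to compound 4 (0.60 log units; beyond the scatter). Compound 4 is expected to give 0.32 nM, within 0.08 nM to 1.3 nM.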

Compound 4, inhibition constant: 0.251 nM
Compound 4: the middle estimate sits 1.3-fold (0.11 log units) above what was measured; measured number inside the range.
By their numbers in this assay, from the lowest: compound 2; then compound 4; then compound 3; then compound 1.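

In this assay, methoxymethyl in place of carbamoyl on a saturated chain carbon bound to an amine nitrogen gives a 2.5-fold higher number from compound 2 to compound 4 (0.40 log units; beyond the scatter) and keeps the number low, so the carbamoyl is not required for a sub-nanomolar number, although compound 2 remains lower. The steps of a 5.0-fold lower number from compound 3 to compound 4 (0.70 log units; beyond the scatter) and a 16-fold lower number from compound 1 to compound 4 (1.20 log units; beyond the scatter) show that (2-methoxyethyl)amino also outperforms both substituents on compound 3 and compound 1, but each step changes more than one feature. No evidence is available to explain these differences.

On these data alone, it remains open how much a methyl on the amine nitrogen of compound 4 would raise the number. A carboxylic acid or a longer chain in place of the methoxymethyl also remains to be assessed.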